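This account rests on a few compounds, and the source may have more. Where it says the series, first, only, none or still open, it means among the compounds named here.

Compound 1 `CC[C@@H]1O[C@H](COCc2ccccc2)[C@@H](OCc2ccccc2)[C@H](OCc2ccccc2)[C@H]1O` is a sugar-like ring carrying three benzyl-protected oxygens, a free hydroxyl and an ethyl arm. For the measured compounds named here, in a functional assay on HeLa cells (Homo sapiens) for antiproliferative activity, read by sulforhodamine B assay (on this read-out lower numbers stand for stronger inhibition of growth and higher numbers for weaker inhibition of growth), compound 1 gives 19800 nM, the only plain number among the two measured values. Compound 2 `CC[C@@H]1O[C@H](COCc2ccccc2)[C@@H](OCc2ccccc2)[C@H](OCc2ccccc2)[C@H]1OC(C)=O`, in which the hydroxyl is acetylated, reaches only the limit of the assay: in this assay compound 2 gives > 50000 nM, a limit rather than a number (the limit of > 50000 nM in this assay, at which 1 of the 2 values shown sits). Going by the values given here, the step of an at least 2.5-fold higher number from compound 1 to compound 2 (0.40 log units; beyond the scatter) is the sole measured change, and it touches the hydroxyl, not the ethyl arm.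

Compound 3 `O[C@@H]1[C@@H](OCc2ccccc2)[C@H](OCc2ccccc2)[C@@H](COCc2ccccc2)O[C@H]1CC1CCCCC1` differs from compound 1 at that arm: cyclohexyl in place of methyl on a saturated chain carbon bound to a saturated ring carbon. Among the compounds with values here, no measured step touches this part of the molecule, so the direction of the change is open. Leaving the number close to compound 1, the estimate for compound 3 is 12000 nM, with an expected range of 3000 nM to 50000 nM, and the expected step is a 1.7-fold lower number from compound 1 to compound 3 (0.22 log units; within the scatter).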

Compound 3, concentration for 50% growth inhibition: 9500 nM
Compound 3: the middle estimate sits 1.3-fold (0.10 log units) above what was measured; low and high end bracket the measured number.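

The ethyl arm, untouched by the earlier step, turns out to matter in this assay: cyclohexyl in place of methyl gives a 2.1-fold lower number from compound 1 to compound 3 (0.32 log units; beyond the scatter). The change is modest, but it shows that this position can take cyclohexylmethyl in place of ethyl without losing growth inhibition, and that a carbon-only group here can shift the number. The earlier step spoke only about the hydroxyl, which compound 3 keeps free.

A single step cannot say whether the ring itself or simply the added carbon drives the shift, and a longer chain such as hexyl, or an amine on the arm, would help to separate those readings. Compound 2 remains a limit rather than a number, so the full size of the acetyl step also stays open: the limit of > 50000 nM in this assay, at which 1 of the 3 values shown sits.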